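Bromo to Trifluoromethyl on the Thiourea Aryl

The source may report more compounds than this note shows. Statements on the series, on what has been measured and on what is new or still open speak of the compounds shown alone.

Among the compounds with values here, compound 2 `NC(=O)c1c(NC(=O)c2ccccc2I)sc2c1CCN(C(=S)Nc1ccccc1Br)C2` gives 18900 nM in a functional assay on HL-60 cells (Homo sapiens) for antiproliferative activity, with a stated time of 24 h (on this read-out higher numbers stand for weaker inhibition and lower numbers for stronger inhibition), and sits at the top of the two numbers so far; compound 1 `NC(=O)c1c(NC(=O)c2ccccc2Cl)sc2c1CCN(C(=S)Nc1ccccc1C(F)(F)F)C2` gives 10600 nM in this assay, a gap that lies within the scatter, so the two cannot be ordered. Compound 3 `NC(=O)c1c(NC(=O)c2ccccc2I)sc2c1CCN(C(=S)Nc1ccccc1C(F)(F)F)C2` differs from compound 2 by trifluoromethyl in place of bromo on an aromatic carbon; compound 1 already carries that trifluoromethyl group. Within the data shown here, no measured step covers this exchange. The step from compound 2 to compound 3 is expected to be a 1.4-fold lower number from compound 2 to compound 3 (0.13 log units; within the scatter), nothing beyond the scatter. For compound 3 a value of 14000 nM is estimated, spanning 6000 nM to 35000 nM.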

Compound 3, half-maximal inhibitory concentration: 19700 nM
Beside the measured number, compound 3's estimate is 1.4-fold (0.15 log units) below it; measured number inside the range.
By their numbers in this assay, from the lowest: compounds 1, 2 and 3 (each within the scatter of the next).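

With iodo held fixed, trifluoromethyl in place of bromo on an aromatic carbon, ortho to a large group, leaves the number in this assay within the scatter (a 1.0-fold higher number from compound 2 to compound 3 (0.02 log units; within the scatter)). With trifluoromethyl held fixed, iodo in place of chloro on an aromatic carbon also stays within the scatter (a 1.9-fold higher number from compound 1 to compound 3 (0.27 log units; within the scatter)), so neither exchange separates these compounds. No measurement at hand bears on the reason for this. As far as these compounds go, whether an amine or a carboxylic acid at this aromatic carbon would give a step beyond the scatter remains open.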